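A few compounds are considered here, and "the series" means these few. Any claim that something is new, unique, unknown or untested is made for them only; others in the source may bear on it.

The series rests on a shared core carrying a carboxamide and a pyridyl group, varied at one position. Compound 1 `C[C@@H](Nc1c(C(N)=O)cnc2ccc(-c3cccnc3)cc12)c1ccc(Cl)cc1` gives in an assay on HT-29 cells for inhibition of Serine-protein kinase ATM (Homo sapiens), read by fluorescence, with a stated time of 1 h (on this read-out lower numbers stand for stronger inhibition and higher numbers for weaker inhibition), a value of 109 nM. Compound 2 `NC(=O)c1cnc2ccc(-c3cccnc3)cc2c1NC1CCCCC1` gives in this assay a value of 132 nM, and compound 3 `NC(=O)c1cnc2ccc(-c3cccnc3)cc2c1NCC1CCCCC1` gives in this assay a value of 456 nM. Compound 3 thus shows the highest number of the three: the steps of a 3.5-fold higher number from compound 2 to compound 3 (0.54 log units; beyond the scatter) and a 4.2-fold higher number from compound 1 to compound 3 (0.62 log units; beyond the scatter) both lie beyond the scatter, while the step of a 1.2-fold higher number from compound 1 to compound 2 (0.08 log units; within the scatter) does not.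

Compound 4 `CCC(CC)COc1c(C(N)=O)cnc2ccc(-c3cccnc3)cc12` has not yet been measured. Relative to compound 3 it carries 2-ethylbutoxy in place of (cyclohexylmethyl)amino on an aromatic carbon. Among the measured compounds shown here, none of the measured steps alters the nitrogen itself; they only exchange the group on it, and exchanging cyclohexyl for cyclohexylmethyl already gave the modest weakening a 3.5-fold higher number from compound 2 to compound 3 (0.54 log units; beyond the scatter). For the measured compounds named here, with no measured step that bears directly on the exchange of the amino link for an ether, and with compound 3 already the weakest point measured, the author expects compound 4 to land on the weaker side in this assay, estimated as a step of a 3.3-fold higher number from compound 3 to compound 4 (0.52 log units; beyond the scatter). Compound 4 is therefore estimated at 1500 nM, with a range from 400 nM to 6000 nM.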

Compound 4, half-maximal inhibitory concentration: > 30000 nM
Compound 4: no number, only a limit; the forecaster's own chance of this, stated with the estimate: 15%; middle value at least 20-fold (1.30 log units) from the limit.
By their numbers in this assay, from the lowest: compounds 1 and 2 (each within the scatter of the next); then compound 3. At a limit, above all of these: compound 4.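

In this assay compound 4 gives no number, only a limit of the assay: the limit of > 30000 nM in this assay, at which 1 of the 4 values shown sits. Replacing the amino link together with its group gives the largest steps in the series, an at least 65-fold higher number from compound 3 to compound 4 (1.81 log units; beyond the scatter) and an at least 220-fold higher number from compound 2 to compound 4 (2.35 log units; beyond the scatter), whereas exchanging only the group on the nitrogen reaches no further than a 4.2-fold higher number from compound 1 to compound 3 (0.62 log units; beyond the scatter). This position, on an aromatic carbon ortho to a carbamoyl group and opposite the ring nitrogen, therefore accepts the measured exchanges on the nitrogen far better than this change, in which the substituent goes from 1 hydrogen-bond donor to 0 and loses its six-membered ring.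

The compounds shown leave open whether the loss follows from the oxygen link or from the open 2-ethylbutoxy chain, since both changes arrive together in compound 4. A cyclohexylmethoxy group or a 2-ethylbutylamino group on the same carbon would separate the two, and a sulfur link would show whether the nitrogen can be replaced by any atom other than oxygen.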